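The source may report more compounds than this note shows. Statements on the series, on what has been measured and on what is new or still open speak of the compounds shown alone.

Measured so far:
compound 1 `CCc1ccccc1N(CC(=O)NCc1ccc(OC)c(OC)c1)S(=O)(=O)c1ccc(C)cc1`: 282 nM
compound 2 `Cc1ccc(S(=O)(=O)N(CC(=O)NCc2ccc(Cl)cc2)c2cccnc2)cc1`: < 1450 nM

Both were run in a functional assay on CHO-K1 cells for antagonist activity at prostaglandin E2 receptor EP1 subtype (Homo sapiens), read by FLIPR and calcium flux; on this read-out higher numbers stand for weaker inhibition and lower numbers for stronger inhibition. Compound 1 gives 282 nM there. For compound 2 only a limit is known: the figure < 1450 nM marks the assay limit and not a measured number, so compound 2 stands at the limit of < 1450 nM in this assay, at which 1 of the 2 values shown sits, with no fixed value. Compound 3 `Cc1ccc(S(=O)(=O)N(CC(=O)NCc2ccc(Cl)cc2)c2ncccc2C)cc1` differs from compound 2 by 3-methylpyridin-2-yl in place of pyridin-3-yl on a sulfonamide nitrogen. No measured step of this kind exists among the compounds shown, so the size and direction of the change are open. Compound 3 is expected to give 600 nM, within a range from 120 nM to 3000 nM. The estimated step that the limit leaves unreadable from compound 2 to compound 3 need not exceed the usual scatter.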

Compound 3, inhibition constant: < 1450 nM
Compound 3 gave a limit, no number (the forecaster's own chance of this, stated with the estimate: 25%); the middle value does not contradict the limit.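

Within the data shown here, compound 2 and compound 3 both give only a limit, so no step between them can be read: the limit of < 1450 nM in this assay, at which 2 of the 3 values shown sit. The compounds shown leave open the size and direction of any change when 3-methylpyridin-2-yl replaces pyridin-3-yl on a sulfonamide nitrogen.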